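The source may hold more compounds than are shown below. What is called first, only, known or untested is meant among the compounds shown, and "the series" means these compounds.

Working notes on the series. Compound 1 `COc1ccccc1-c1cnc(C(=O)CCCCCCc2ccccc2)o1` and compound 2 `NC(=O)c1ccc(-c2cnc(C(=O)CCCCCCc3ccccc3)o2)cc1` share one core and differ only in the group attached to it. In an assay (Rattus norvegicus) for inhibition of Fatty-acid amide hydrolase 1 (Homo sapiens) (a lower number here means a stronger inhibitor, a higher number a weaker inhibitor), compound 1 gives 400 nM, and compound 2 gives 10 nM. Among the compounds with values here, the single measured step, a 40-fold lower number from compound 1 to compound 2 (1.60 log units; beyond the scatter), shows that exchanging the group at this aromatic carbon can move the number a long way. Within the data shown here, compound 2 thus stands at the lowest of the two numbers so far, with compound 1 the nearest at a much higher number.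

Compound 3 `Cc1ccc(-c2cnc(C(=O)CCCCCCc3ccccc3)o2)nc1` is the next member. Its change from compound 2: 5-methylpyridin-2-yl in place of 4-carbamoylphenyl on an aromatic carbon. Among the measured compounds shown here, the only step that bears on it is a 40-fold lower number from compound 1 to compound 2 (1.60 log units; beyond the scatter), which also exchanged the group at this carbon; that step was large and coincided with the arrival of the 4-carbamoylphenyl group that compound 3 now gives up. The 5-methylpyridin-2-yl group has not been seen before in the series, so the size is uncertain, but a partial move back toward the number of compound 1 is expected. The expected step is a 10-fold higher number from compound 2 to compound 3 (1.00 log units; beyond the scatter), a higher number in this assay. Compound 3 is estimated at 100 nM, within 20 nM to 500 nM.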

Compound 3, inhibition constant: 2.8 nM
Compound 3: middle estimate off by 36-fold (1.55 log units), on the high side; the whole stated range lies above it.
By their numbers in this assay, from the lowest: compound 3; then compound 2; then compound 1.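

The 4-carbamoylphenyl group is not required for a low number at this aromatic carbon of the shared core: 5-methylpyridin-2-yl in its place gives a 3.6-fold lower number from compound 2 to compound 3 (0.55 log units; beyond the scatter) in this assay. The entering group carries no hydrogen-bond donor and has fewer heavy atoms than the group it replaces, so neither the donor of the 4-carbamoylphenyl group nor its larger atom count is needed to reach this range. Against the 2-methoxyphenyl group the same substituent gives a 140-fold lower number from compound 1 to compound 3 (2.15 log units; beyond the scatter), which widens the span seen at this position and places compound 3 lowest of the three, with both of its steps beyond the scatter. No measurement shown explains this result.

Going by these compounds, what a pyridin-2-yl group without the methyl would give remains open, and with it how the step divides between the ring nitrogen and the methyl. The compounds shown also leave open how an amine or a carboxylic acid on that six-membered ring would read, and whether the step would hold with a shorter chain on the carbonyl.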